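The source may report more compounds than this note shows. Statements on the series, on what has been measured and on what is new or still open speak of the compounds shown alone.

Measured compounds:
compound 1, `Cc1ccc(CNC(=O)c2nc(-c3ccc(F)cc3)n(CC[C@@H](O)C[C@@H](O)CC(=O)O)c2C2CC2)cc1`, 178 nM
compound 2, `CC(C)c1c(C(=O)NCc2ccccc2)nc(-c2ccc(F)cc2)n1CC[C@@H](O)C[C@@H](O)CC(=O)O`, 3030 nM
compound 3, `O=C(O)C[C@H](O)C[C@H](O)CCn1c(-c2ccc(F)cc2)nc(C(=O)NCc2ccccc2F)c1C1CC1`, 27200 nM

All three were tested in a functional assay on L6 cells (Rattus norvegicus) for inhibition, read by scintillation counting, with a stated time of 3 h; a higher number here means a weaker inhibitor, a lower number a stronger inhibitor. Compound 3 has the highest number of the three, so it is the weakest inhibitor here; its nearest neighbour is compound 2, and the gap to compound 1 is the widest. For the measured compounds named here, only one step among the measured compounds is a single-point change: a 150-fold higher number from compound 1 to compound 3 (2.18 log units; beyond the scatter). That step replaced 4-methylphenyl with 2-fluorophenyl and cost a great deal.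

Compound 4, `O=C(O)C[C@H](O)C[C@H](O)CCn1c(-c2ccc(F)cc2)nc(C(=O)NCc2ccc(F)cc2)c1C1CC1`, has not yet been measured. It differs from compound 3 by 4-fluorophenyl in place of 2-fluorophenyl on a saturated chain carbon bound to an amide-type nitrogen. The 4-fluorophenyl of compound 4 has its fluorine where compound 1 carried its methyl, while only the fluorine's position changes relative to compound 3. Because compound 3 stands at 27200 nM and compound 1 at 178 nM, the change is expected to move the number downward, well beyond the scatter, though the data do not show whether the 4-substituent matters as much as the 2-substituent. The step of a 39-fold lower number from compound 3 to compound 4 (1.59 log units; beyond the scatter) is therefore expected to be a large drop. Compound 4 is estimated at 700 nM, within a range from 150 nM to 4000 nM.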

Compound 4, half-maximal inhibitory concentration: 1620 nM
Estimate against measurement, compound 4: 2.3-fold (0.36 log units) below; low and high end bracket the measured number.
By their numbers in this assay, from the lowest: compound 1; then compounds 4 and 2 (each within the scatter of the next); then compound 3.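

In this assay, moving the fluorine alone, from 2-fluorobenzyl to 4-fluorobenzyl, gives a 17-fold lower number from compound 3 to compound 4 (1.23 log units; beyond the scatter) and so shows that where the fluorine sits on this ring matters, not only that it is present. The 4-substituent also counts: a 9.1-fold higher number from compound 1 to compound 4 (0.96 log units; beyond the scatter) remains after fluoro takes the place of methyl on the aromatic carbon, so 4-fluorophenyl does not fully match 4-methylphenyl at this place. The earlier step of a 150-fold higher number from compound 1 to compound 3 (2.18 log units; beyond the scatter) can now be read as two changes, a swap of methyl for fluoro and a shift of the fluorine, each beyond the usual scatter, although nothing shown explains why either one moves the number.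

With only methyl and fluoro shown at the 4-position, it remains open whether a larger group such as 4-chlorophenyl or 4-methoxyphenyl would lie closer to compound 1 or to compound 4. Going by these compounds, it is also open whether the large rise seen with 2-fluorophenyl belongs to fluorine alone or to any group at that spot, which a 2-methylphenyl analogue on the same core could help to settle.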